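This account rests on a few compounds, and the source may have more. Where it says the series, first, only, none or still open, it means among the compounds named here.

Compound 1 `CCn1c(-c2nnc(N(C)Cc3ccc4nccn4c3)o2)nc2ccccc21` in an assay on isolated protein for inhibition of tyrosine-protein kinase receptor TYRO3 (Homo sapiens), read by LC-MS, with stated times of 30 min and 180 min (on this read-out lower numbers stand for stronger inhibition and higher numbers for weaker inhibition), gives 39800 nM. Compound 2 `CNC(=O)c1sc(N2CC3CC2(CNC(=O)c2c[nH]c4ncc(C(F)(F)F)cc24)C3)nc1C(F)(F)F` in this assay gives no number, only a limit of > 100000 nM, which is the limit of > 100000 nM in this assay, at which 1 of the 2 values shown sits. Compound 3 `CNC(=O)c1sc(N2CC3CC2(CNC(=O)c2c[nH]c4ncccc24)C3)nc1C(F)(F)F` differs from compound 2 by hydrogen in place of trifluoromethyl on an aromatic carbon. For the measured compounds named here, no measured step shows what such a change does here, so the step is expected to stay within the usual scatter: a number no higher from compound 2 to compound 3 (the limit leaves the size open). Compound 3 is therefore expected to give about 100000 nM, somewhere between 30000 nM and 300000 nM, and may again be reported only as a limit.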

Compound 3, half-maximal inhibitory concentration: 2000 nM
The estimate for compound 3 lay 50-fold (1.70 log units) above the measured number, and the stated range ends above it.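

In this assay, hydrogen in place of trifluoromethyl on this aromatic carbon brings an at least 50-fold lower number from compound 2 to compound 3 (1.69 log units; beyond the scatter). For the compounds shown here, this is the first sign that the group at this one place strongly shifts the read-out in this pair, with the hydrogen compound the stronger inhibitor. Compound 2 gives only a limit, so the step sets a minimum size and not an exact one: the limit of > 100000 nM in this assay, at which 1 of the 3 values shown sits.

Still open, going by these compounds, is how other groups at this carbon, such as methyl, chlorine or a nitrile, would read. The two compounds cannot tell whether only trifluoromethyl weakens inhibition or other groups there would too.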